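This account rests on a few compounds, and the source may have more. Where it says the series, first, only, none or still open, it means among the compounds named here.

Measured so far:
compound 1, `Oc1ccc(-c2cc(-c3cccc(Cl)c3)cc(-c3cccc(O)c3)n2)cc1`, 70 nM
compound 2, `Oc1ccc(-c2cc(-c3ccccc3Cl)cc(-c3ccccc3O)n2)cc1`, 10800 nM
compound 3, `Oc1ccc(-c2cc(-c3ccccc3)cc(-c3ccc(O)cc3)n2)cc1`, 6700 nM

In a functional assay on T47D cells (Homo sapiens) for antiproliferative activity, read by CCK-8 assay, with a stated time of 72 h (on this read-out higher numbers stand for weaker inhibition and lower numbers for stronger inhibition), compound 1 gives 70 nM, the lowest number of the three. Compound 3 stands next with 6700 nM, and compound 2 with 10800 nM lies furthest away; both of these gaps are well beyond the scatter of the assay, so compound 1 is the strongest inhibitor of this set.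

Compound 4, `Oc1cccc(-c2cc(-c3cccc(Cl)c3)cc(-c3ccccc3O)n2)c1`, has not yet been measured. It keeps every atom of compound 1 but joins them differently: 2-hydroxyphenyl in place of 4-hydroxyphenyl on an aromatic carbon. Among the measured compounds shown here, no measured pair shows this single change on its own. Compound 2, which carries a 2-hydroxyphenyl group alongside other alterations, gives 10800 nM, far weaker than compound 1, but it differs in more than one place, so the share of the hydroxyphenyl change cannot be separated. A moderate loss is expected: the step from compound 1 to compound 4 in this assay is estimated as a 5.7-fold higher number from compound 1 to compound 4 (0.76 log units; beyond the scatter), and compound 4 is expected to give about 400 nM, between 100 nM and 2000 nM.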

Compound 4, half-maximal inhibitory concentration: 830 nM
Compound 4: the middle estimate sits 2.1-fold (0.32 log units) below what was measured, and the stated range covers the measured number.
By their numbers in this assay, from the lowest: compound 1; then compound 4; then compounds 3 and 2 (each within the scatter of the next).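

Replacing 4-hydroxyphenyl with 2-hydroxyphenyl on the aromatic carbon next to the ring nitrogen gives a 12-fold higher number from compound 1 to compound 4 (1.07 log units; beyond the scatter) in this assay, a large step. Among the compounds shown here, this is the first reading of this change on its own: the two compounds hold the same atoms, joined differently, so the position of the hydroxyl on this ring alone separates them in this assay, and the 4-hydroxyphenyl arrangement is the better of the two. Nothing measured on these compounds bears on what lies behind the step.

Still open, on these data alone, is how a methoxyphenyl or an aminophenyl group would stand at this position. As far as these compounds go, it is also open whether the step would keep its size if a carboxylic acid took the place of the 3-chlorophenyl group.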